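The source may hold more compounds than are shown below. What is called first, only, known or untested is meant among the compounds shown, and "the series" means these compounds.

In a functional assay on A549 cells (Homo sapiens) for cytotoxicity, read by MTT assay, with a stated time of 72 h; on this read-out higher numbers stand for weaker inhibition and lower numbers for stronger inhibition:
- Compound 1 `CC1CCN(Cc2ccc3nc(NC(=O)N/N=C/c4cn(Cc5cccc(Cl)c5)c5ccccc45)sc3c2)CC1`: 2810 nM
- Compound 2 `CC1CCN(Cc2ccc3nc(NC(=O)N/N=C/c4c[nH]c5ccccc45)sc3c2)CC1`: 3580 nM
- Compound 3 `CC1CCN(Cc2ccc3nc(NC(=O)N/N=C/c4cn(Cc5ccccc5)c5ccccc45)sc3c2)CC1`: 2340 nM

Compound 3 gives 2340 nM, and it cannot be separated from the other two compounds: a 1.2-fold lower number from compound 1 to compound 3 (0.08 log units; within the scatter) and a 1.5-fold lower number from compound 2 to compound 3 (0.18 log units; within the scatter) both lie within the usual scatter.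

Compound 4 `CC1CCN(Cc2ccc3nc(NC(=O)N/N=C/c4cn(Cc5ccc(C(C)(C)C)cc5)c5ccccc45)sc3c2)CC1` changes compound 3 in one place: tert-butyl in place of hydrogen on an aromatic carbon. This puts tert-butyl in place of hydrogen on an aromatic carbon, turning benzyl into 4-(tert-butyl)benzyl.

Among the measured compounds shown here, two measured steps bear on this. The closest is a 1.2-fold lower number from compound 1 to compound 3 (0.08 log units; within the scatter), which also swaps a group on that ring for hydrogen. The other, a 1.3-fold higher number from compound 1 to compound 2 (0.11 log units; within the scatter), removes the whole 3-chlorobenzyl group and still stays within the scatter. For the measured compounds named here, no measured compound carries tert-butyl, so this remains an extrapolation, and no direction is favoured.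

The expected result in this assay is a 1.0-fold lower number from compound 3 to compound 4 (0.01 log units; within the scatter), with no shift beyond the scatter anticipated. The estimate for compound 4 is 2300 nM, with an expected range from 1100 nM to 4800 nM.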

Compound 4, half-maximal inhibitory concentration: 3710 nM
For compound 4 the middle estimate is 1.6-fold (0.21 log units) below the measured one; low and high end bracket the measured number.
By their numbers in this assay, from the lowest: compounds 3, 1, 2 and 4 (each within the scatter of the next).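

In this assay, compound 4 is the only compound shown with a group on this aromatic carbon, para to a large group, and adding tert-butyl there stays within the scatter: a 1.6-fold higher number from compound 3 to compound 4 (0.20 log units; within the scatter). The whole 4-(tert-butyl)benzyl group also stays within the scatter when it replaces hydrogen on the aromatic nitrogen, a 1.0-fold higher number from compound 2 to compound 4 (0.02 log units; within the scatter), and when it is compared with the 3-chlorobenzyl group, a 1.3-fold higher number from compound 1 to compound 4 (0.12 log units; within the scatter). So even this larger substituent gives no separable change in cytotoxicity on these cells, and no supporting measurement is available to explain the result.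

As far as these compounds go, what an amine, a carboxylic acid or a methoxy group would do on this same aromatic carbon remains open. It is also unknown whether any group at this position can move the number beyond the scatter.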